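Arylamino swap on a urea series, single-dose cell inhibition

A few compounds are considered here, and "the series" means these few. Any claim that something is new, unique, unknown or untested is made for them only; others in the source may bear on it.

Measured in a functional assay on NCI-H1581 cells (Homo sapiens) for inhibition, read by MTT assay, with a stated time of 48 h, tested at 10 uM; a lower number here means less inhibition, a higher number more inhibition at the concentration tested (going by the name of the read-out):
compound 1 `CCc1ccc(Nc2cc(NC(=O)Nc3cc(OC)cc(OC)c3)ncn2)cc1` gives 32.7%
compound 2 `COc1cc(NC(=O)Nc2cc(Nc3ccc(F)c(Cl)c3)ncn2)cc(OC)c1` gives 53%
compound 3 `O=C(Nc1cc(Nc2ccc(F)c(Cl)c2)ncn1)Nc1c(Cl)cccc1Cl` gives 67%

Compound 3 stands highest of the three, beyond the scatter from compound 2 and from compound 1. Among the compounds with values here, the only change measured on its own in this assay is 4-ethylphenyl in place of 3-chloro-4-fluorophenyl on a nitrogen on an aromatic ring, which gave a number 20.3 percentage points lower from compound 2 to compound 1 (beyond the scatter). Compound 4 `CCc1ccc(Nc2cc(NC(=O)Nc3c(Cl)cccc3Cl)ncn2)cc1` carries the same change on the core of compound 3: 4-ethylphenyl in place of 3-chloro-4-fluorophenyl on a nitrogen on an aromatic ring. The cores of compound 2 and compound 3 differ, but the difference between the two cores is not broken down here, so the transfer rests on one pair alone. Compound 4 is expected to fall below compound 3 by about the earlier step, a number 20 percentage points lower from compound 3 to compound 4 (beyond the scatter), because the same change gave a number 20.3 percentage points lower from compound 2 to compound 1 (beyond the scatter). Compound 4 is estimated at 47%, expected between 30% and 62%.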

Compound 4, a percentage reported as inhibition, at one concentration (the size of the read-out at that concentration, not a potency): 38.1%
The estimate for compound 4 lay 8.9 percentage points above the measured number; low and high end bracket the measured number.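

In this assay, 4-ethylphenyl in place of 3-chloro-4-fluorophenyl on the nitrogen again lowers the number, a number 28.9 percentage points lower from compound 3 to compound 4 (beyond the scatter). The change carries across these two cores with a similar size: the same change on two cores in this assay, a number 20.3 percentage points lower (beyond the scatter) from compound 2 to compound 1 and a number 28.9 percentage points lower (beyond the scatter) from compound 3 to compound 4, 8.6 percentage points apart, within the scatter of two such steps

This rests on two pairs at a single concentration, so it supports direction and rough size on the cores of compound 2 and compound 3 only, and it says nothing about potency or about other cores. Still open, going by these compounds, is whether the step holds with an amine or a longer chain in place of the ethyl group. A carboxylic acid on the aryl group of the urea would test the transfer on a further core.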